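Changing the aryl group on the ring nitrogen

A few compounds are considered here, and "the series" means these few. Any claim that something is new, unique, unknown or untested is made for them only; others in the source may bear on it.

compound 1 `CC(C)(C)c1ccc(-n2nc(-c3ccc(C(F)(F)F)cc3O)nc2-c2ccccc2O)cc1`: 67.3%
compound 2 `Oc1cc(C(F)(F)F)ccc1-c1nc(-c2ccccc2O)n(-c2ccccc2C(F)(F)F)n1`: 71%

In a functional assay on PC-12 cells (Rattus norvegicus) for cytotoxicity, read by MTT assay, with stated times of 2 h and 24 h, tested at 1 uM (on this read-out lower numbers stand for a weaker effect and higher numbers for a stronger effect at the one concentration tested), compound 1 gives 67.3% and compound 2 gives 71%. The step of a number 3.7 percentage points higher from compound 1 to compound 2 (within the scatter) lies within the scatter, so compound 2 cannot be set apart from compound 1 on these two numbers.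

Compound 3 `Oc1cc(C(F)(F)F)ccc1-c1nc(-c2ccccc2O)n(-c2ccc(Cl)cc2Cl)n1` differs from compound 2 by 2,4-dichlorophenyl in place of 2-(trifluoromethyl)phenyl on an aromatic nitrogen. Within the data shown here, the one measured step, from compound 1 to compound 2, also replaced the group on the aromatic nitrogen and stayed within the scatter, so no step beyond the scatter is expected here either. Compound 3 is therefore estimated at 70%, between 58% and 82%. The expected step of a number 1 percentage points lower from compound 2 to compound 3 (within the scatter) stays within the scatter.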

Compound 3, a percentage reported as activity, at one concentration (the size of the read-out at that concentration, not a potency): 69%
Estimate against measurement, compound 3: 1 percentage points above, within the range that was stated.
By their numbers in this assay, from the lowest: compounds 1, 3 and 2 (each within the scatter of the next).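

On this assay the aromatic nitrogen now shows a third aryl group with no step beyond the scatter: 2,4-dichlorophenyl gives a number 2 percentage points lower from compound 2 to compound 3 (within the scatter) and also a number 1.7 percentage points higher from compound 1 to compound 3 (within the scatter) when set against 4-(tert-butyl)phenyl. Among these three compounds, then, chlorine, trifluoromethyl and tert-butyl substituents on this phenyl ring cannot be told apart. Nothing available explains why the number holds so steady.

On these data alone, all three compounds keep a substituted phenyl ring here, so the effect of an amine, a carboxylic acid or a longer alkyl chain on this nitrogen remains open. A reading at one concentration also leaves potency open.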